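Inverting one ring stereocentre in compound 1

The compounds below may be only part of what the source reports. "The series", "measured", "known", "first", "only" and "open" are said of these compounds alone.

Compound 1 `Nc1ncc(-c2cc([C@@H]3CCCO3)nc(N3C[C@@H]4C[C@H]3CO4)n2)nc1OC(F)F` gives 23 nM in an assay on Sf21 cells for inhibition of mitogen-activated protein kinase kinase kinase 13 (Homo sapiens), read by HTRF, with a stated time of 1.5 h (a lower number here means a stronger inhibitor, a higher number a weaker inhibitor), and has the lower of the two numbers recorded so far, the other being compound 2 `Nc1ncc(-c2cc(N3C[C@@H]4C[C@H]3CO4)nc(N3CC4CC3C4)n2)nc1C(F)(F)F` at 149 nM. Compound 3 `Nc1ncc(-c2cc([C@H]3CCCO3)nc(N3C[C@@H]4C[C@H]3CO4)n2)nc1OC(F)F` differs from compound 1 only in configuration: the two compounds have the same atoms and bonds and differ only in configuration as drawn: 1 of 3 stereo elements differ; a stereocentre at a saturated ring carbon is drawn S in compound 1 and R in compound 3. No measured pair in this series changes configuration alone, so the size of such a step is not shown by the data. A modest loss is expected, the step from compound 1 to compound 3 estimated as a 2.6-fold higher number from compound 1 to compound 3 (0.42 log units; beyond the scatter). For compound 3 the expected value is 60 nM, with a range of 15 nM to 250 nM.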

Compound 3, half-maximal inhibitory concentration: 202 nM
Compound 3: middle estimate off by 3.4-fold (0.53 log units), on the low side, and the stated range covers the measured number.
By their numbers in this assay, from the lowest: compound 1; then compounds 2 and 3 (each within the scatter of the next).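

At the saturated ring carbon, configuration alone moves the number in this assay, with S to R giving an 8.8-fold higher number from compound 1 to compound 3 (0.94 log units; beyond the scatter) and so marking S as the better of the two drawn forms. Among these compounds, this is the first pair to isolate a single stereocentre, and the size of the step shows that this position responds to configuration. The step can be assigned to that stereocentre alone because of one fact: the fact that compounds 1 and 3 differ only in the configuration as drawn.

As far as these compounds go, it remains open whether the S preference holds with the difluoromethoxy group in place of another group on the shared core. From the compounds shown here alone, it also remains open whether an open-chain methoxyethyl group or a primary amine at this position would keep the number of compound 1.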